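Trimethoxyphenyl imidazopyridine series: removing the para fluorine

The source may hold more compounds than are shown below. What is called first, only, known or untested is meant among the compounds shown, and "the series" means these compounds.

Measured compounds:
Compound 1, `COc1cc(-c2nccn3cc(-c4ccc(C(F)(F)F)cc4)nc23)cc(OC)c1OC`, 2630 nM
Compound 2, `COc1cc(-c2nccn3cc(-c4ccc(N)cc4)nc23)cc(OC)c1OC`, 252 nM
Compound 3, `COc1cc(-c2nccn3cc(-c4ccc(F)cc4)nc23)cc(OC)c1OC`, 217 nM

All three share one core and differ only in the group on the pendant six-membered aromatic ring. In a functional assay on HepG2 cells (Homo sapiens) for inhibition, read by MTT assay, with a stated time of 48 h (on this read-out lower numbers stand for stronger inhibition and higher numbers for weaker inhibition), compound 3 gives the lowest of the three numbers, though compound 2 sits within the scatter of it, a 1.2-fold lower number from compound 2 to compound 3 (0.06 log units; within the scatter), so the two cannot be ranked against each other. Compound 1 stands well apart: a 12-fold lower number from compound 1 to compound 3 (1.08 log units; beyond the scatter) and a 10-fold lower number from compound 1 to compound 2 (1.02 log units; beyond the scatter).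

Compound 4, `COc1cc(-c2nccn3cc(-c4ccccc4)nc23)cc(OC)c1OC`, has not yet been measured. Its structure differs from compound 3 in one place: hydrogen in place of fluoro on an aromatic carbon.

Of the measured steps, none exchanges fluoro for hydrogen, so the bearing is indirect. For the measured compounds named here, the two large steps both concern trifluoromethyl leaving, and the only step between two small groups, a 1.2-fold lower number from compound 2 to compound 3 (0.06 log units; within the scatter), lies within the scatter. Taken together these suggest that a small group at this place leaves the number roughly where it is, and that only the large trifluoromethyl group has moved it. Compound 4 is therefore expected to give about a 1.4-fold higher number from compound 3 to compound 4 (0.14 log units; within the scatter) in this assay, a step expected to lie within the scatter. The estimate for compound 4 is 300 nM, with a range from 120 nM to 800 nM.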

Compound 4, half-maximal inhibitory concentration: 267 nM
For compound 4 the middle estimate is 1.1-fold (0.05 log units) above the measured one; low and high end bracket the measured number.
By their numbers in this assay, from the lowest: compounds 3, 2 and 4 (each within the scatter of the next); then compound 1.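

Taking away the fluorine gives the first direct reading of hydrogen at this place on the pendant ring. In this assay the step of a 1.2-fold higher number from compound 3 to compound 4 (0.09 log units; within the scatter) and the step of a 1.1-fold higher number from compound 2 to compound 4 (0.03 log units; within the scatter) both stay within the scatter, so hydrogen, fluoro and amino cannot be told apart here, and the ring needs neither of the two groups to give a number in this range. For the compounds shown here, with the unsubstituted phenyl ring now available as a reference, trifluoromethyl is the one group of the four that stands apart, as the step of a 9.9-fold lower number from compound 1 to compound 4 (0.99 log units; beyond the scatter) shows, and nothing available here explains that difference.

The compounds shown leave open where the change sets in between these small groups and trifluoromethyl, and whether a methoxy group, a chlorine atom, a carboxylic acid or a longer alkyl chain at this place would stay with hydrogen, fluoro and amino or fall with trifluoromethyl. They also leave open whether this same grouping of the four compounds would hold in any cell line other than this one.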